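A Halophenyl Swap on the Enone Chain

A few compounds are considered here, and "the series" means these few. Any claim that something is new, unique, unknown or untested is made for them only; others in the source may bear on it.

Among the measured compounds shown here, compound 2 `Cc1ccc(S(=O)(=O)NC(=O)Nc2ccccc2C(=O)/C=C/c2cccc(F)c2)cc1` gives 4.13 ug/mL in an ADME assay on the whole organism for cytotoxicity, with Artemia salina as the target, with a stated time of 24 h (a higher number here means that more compound is needed for the effect, a lower number that less compound is needed), the lowest of the two numbers measured so far. For the measured compounds named here, its only measured neighbour, compound 1 `CCOc1cc(/C=C/C(=O)c2ccccc2NC(=O)NS(=O)(=O)c2ccc(C)cc2)ccc1O`, gives 19.2 ug/mL, and the step of a 4.6-fold lower number from compound 1 to compound 2 (0.67 log units; beyond the scatter) is the single comparison available. Compound 3 `Cc1ccc(S(=O)(=O)NC(=O)Nc2ccccc2C(=O)/C=C/c2ccccc2Cl)cc1` has not yet been measured; it differs from compound 2 by 2-chlorophenyl in place of 3-fluorophenyl on a double-bonded chain carbon bound to a double-bonded chain carbon. The measured step replaced a hydroxy- and ethoxy-bearing ring with the 3-fluorophenyl ring, so it bears only loosely on the present change, in which the ring that enters matches the ring that leaves in its count of heavy atoms, donors and acceptors. Going by the values given here, with no closer precedent, the step from compound 2 to compound 3 is expected to stay within the usual scatter, estimated as a 1.1-fold lower number from compound 2 to compound 3 (0.04 log units; within the scatter). Compound 3 is therefore expected to give about 3.8 ug/mL in this assay, with a range from 1.3 ug/mL to 11 ug/mL.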

Compound 3, concentration for half-maximal effect: 12.8 ug/mL
The estimate for compound 3 lay 3.4-fold (0.53 log units) below the measured number, outside the stated range (above it).
By their numbers in this assay, from the lowest: compound 2; then compounds 3 and 1 (each within the scatter of the next).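

Exchanging one halophenyl ring for another with the same counts of heavy atoms, donors and acceptors still moved the number in this assay, giving a 3.1-fold higher number from compound 2 to compound 3 (0.49 log units; beyond the scatter) at this place on a double-bonded chain carbon bound to a double-bonded chain carbon, so those counts alone do not settle the outcome here. Set against the much larger exchange of the 3-ethoxy-4-hydroxyphenyl ring, 2-chlorophenyl gives a 1.5-fold lower number from compound 1 to compound 3 (0.18 log units; within the scatter) and so does not share the low number of the 3-fluorophenyl ring. No measurement is at hand that would account for this difference.

The compounds shown leave open whether the step follows the identity of the halogen or its place on the ring, as both change together from 3-fluorophenyl to 2-chlorophenyl. They also leave open how 3-chlorophenyl, 2-fluorophenyl or an aminophenyl ring would read in this assay at this place.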